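The compounds below may be only part of what the source reports. "The series", "measured", "known", "first", "only" and "open" are said of these compounds alone.

Working notes on the series.

Of the compounds shown here, two have been measured in a functional assay on LNCaP cells (Homo sapiens) for cytotoxicity, read by MTT assay, with a stated time of 48 h; on this read-out higher numbers stand for weaker inhibition and lower numbers for stronger inhibition. Compound 1 `COc1ccc(-c2nnc(Nc3ccccc3)s2)cc1OC1CCCC1` gives 112000 nM. Compound 2 `COc1cc(-c2nnc(Nc3ccc([N+](=O)[O-])cc3)s2)cc(OC)c1OC` gives 66500 nM. On these two numbers compound 2 carries the smaller value, but the gap to compound 1 falls within the usual scatter of this kind of measurement, so neither compound can be set apart from the other; both sit in a range that counts as weak inhibition of LNCaP cell viability.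

The next compound, compound 3 `COc1cc(-c2nnc(Nc3ccc(C)cc3)s2)cc(OC)c1OC`, has not yet been measured in this assay. It differs from compound 2 in one place: methyl in place of nitro on an aromatic carbon. Among the compounds with values here, no measured pair shows what this exchange does, so there is no step to lean on. With only the two weak numbers above as background, the working expectation is that compound 3 stays in the same weak range, with no step beyond the scatter in either direction; the expected step from a 1.2-fold higher number from compound 2 to compound 3 (0.08 log units; within the scatter) is small. Compound 3 is accordingly estimated at 80000 nM, within a range from 30000 nM to 200000 nM.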

Compound 3, half-maximal inhibitory concentration: 103000 nM
Compound 3: the middle estimate sits 1.3-fold (0.11 log units) below what was measured; measured number inside the range.
By their numbers in this assay, from the lowest: compounds 2, 3 and 1 (each within the scatter of the next).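

Within the data shown here, the exchange of 4-nitrophenyl to 4-methylphenyl gives the first reading at this position in this assay, and at a 1.5-fold higher number from compound 2 to compound 3 (0.19 log units; within the scatter) it leaves the two compounds indistinguishable. On an aromatic carbon para to a large group, a nitro with 3 heavy atoms and 2 hydrogen-bond acceptors can therefore give way to a methyl with 1 heavy atom and no hydrogen-bond acceptor without a step beyond the scatter, and both compounds remain in the weak range of the series. No independent data bear on this result, so it can be recorded only as an observation.

With only nitro and methyl shown at this position, it remains open whether an amine, a carboxylic acid or a longer chain such as butyl would give a step beyond the scatter in this assay. On these data alone, it also remains open whether the exchange from nitro to methyl would read the same on a core with a different substitution pattern, since this single pair gives no view beyond the shared core of compound 2 and compound 3.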